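The source may report more compounds than this note shows. Statements on the series, on what has been measured and on what is new or still open speak of the compounds shown alone.

In a functional assay on HCT-116 cells (Homo sapiens) for cytotoxicity, read by MTT assay, with a stated time of 48 h (a lower number here means a stronger inhibitor of growth, a higher number a weaker inhibitor of growth), compound 1 (`Cc1nc2cc(Cl)c(Cl)cc2[nH]1`) stands at 51000 nM and compound 2 (`O=[N+]([O-])c1cccc(Cn2c(C(F)(F)F)nc3cc(Cl)c(Cl)cc32)c1`) at 22800 nM while compound 3 (`Clc1cc2ncn(C3CCCC3)c2cc1Cl`) stands at 37000 nM as the second highest of the three numbers and within the usual scatter of both others. Compound 4 (`Cc1nc2cc(Cl)c(Cl)cc2n1C1CCCC1`) differs from compound 3 by a single change (methyl in place of hydrogen on an aromatic carbon) with methyl in place of hydrogen on an aromatic carbon, between two ring nitrogen atoms and next to the ring atom that bears a cyclopentyl group. Going by the values given here, no two measured compounds differ in one place only, so no measured step shows what this change does. Compound 1 carries methyl on that same carbon but no cyclopentyl group, and at 51000 nM it lies within the scatter of compound 3 at 37000 nM so these two values offer no clear signal for the methyl. In this assay no step beyond the scatter is therefore expected, and the data favour no direction. The estimated step is a small one (a 1.1-fold lower number from compound 3 to compound 4 (0.05 log units; within the scatter)) and is expected to stay within the scatter. For compound 4 the estimated value is 33000 nM in an expected range from 14000 nM to 70000 nM on the evidence of these few measurements.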

Compound 4, concentration for 50% growth inhibition: 13000 nM
For compound 4 the middle estimate is 2.5-fold (0.40 log units) above the measured one, and the stated range ends above it.
By their numbers in this assay, from the lowest: compounds 4, 2, 3 and 1 (each within the scatter of the next, the first and the last beyond it).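

In this assay, going by these compounds alone, the methyl on the aromatic carbon between two ring nitrogen atoms now has a measured effect, which none of the earlier compounds could show on their own: with the cyclopentyl group present, the step is a 2.8-fold lower number from compound 3 to compound 4 (0.45 log units; beyond the scatter) and so marks a modest gain in growth inhibition. The cyclopentyl group on the aromatic nitrogen can now be read as well, and with the methyl present the step is a 3.9-fold lower number from compound 1 to compound 4 (0.59 log units; beyond the scatter), again modest and in the same direction. Compound 4, carrying both groups, thus stands beyond the scatter of compound 3 and of compound 1, though nothing on hand explains either step.

As far as these compounds go, how an ethyl group, a longer chain or an amine on that same carbon would compare with the methyl remains open, as does how a cyclohexyl group on the aromatic nitrogen would compare with the cyclopentyl group. Also open, from the compounds shown here alone, is whether the methyl would give a similar step on the shared core with only hydrogen on the aromatic nitrogen, and whether either step would carry over to cells other than those of this assay.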